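Protein binding notes: compound 3 to compound 4

This account rests on a few compounds, and the source may have more. Where it says the series, first, only, none or still open, it means among the compounds named here.

- compound 1 `CC(C)N(c1cc(C#CC(C)(C)C)sc1C(=O)O)C(=O)[C@H]1CC[C@H](C)CC1` gives 0.06
- compound 2 `CC(C)N(c1cc(C#CC(C)(C)C)sc1C(=O)O)C(=O)[C@H]1CC[C@H](CF)CC1` gives 0.18
- compound 3 `CON=C1CCC(N(c2cc(C#CC(C)(C)C)sc2C(=O)O)C(=O)[C@H]2CC[C@H](C)CC2)CC1` gives 0.07
- compound 4 `CC(C)(C)C#Cc1cc(N(C(=O)[C@H]2CC[C@H](C)CC2)[C@H]2CC[C@H](O)CC2)c(C(=O)O)s1` is not yet measured

In an ADME assay for protein binding, using equilibrium dialysis, at pH 7.4, tested at 2 uM (on this read-out lower numbers stand for a smaller free fraction and higher numbers for a larger free fraction), compound 3 stands at 0.07, within the scatter of compound 1 at 0.06, while compound 2 at 0.18 has the highest number of the three.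

The change to compound 4 brings in 4-hydroxycyclohexyl on an amide-type nitrogen: a group of 7 heavy atoms (6 carbon, 1 oxygen; one six-membered non-aromatic ring of carbon only) in place of a group of 9 heavy atoms (7 carbon, 1 nitrogen, 1 oxygen; one six-membered non-aromatic ring of carbon only), on an amide-type nitrogen.

Among the compounds with values here, two measured steps bear on this, and neither is the same change. The closer one, a 1.2-fold higher number from compound 1 to compound 3 (0.07 log units; within the scatter), is a swap of groups on that same amide-type nitrogen and shows no shift beyond the scatter. The other, a 3.0-fold higher number from compound 1 to compound 2 (0.48 log units; beyond the scatter), is a fluoro-for-hydrogen change on a saturated chain carbon, and it shows that this assay can move beyond the scatter within these compounds. Within the data shown here, no measured compound carries 4-hydroxycyclohexyl, so the direction is not settled by the data. A small upward move is the working expectation, with no step beyond the scatter foreseen. The expected size is a 1.4-fold higher number from compound 3 to compound 4 (0.15 log units; within the scatter). For compound 4 the estimate is 0.1, with an expected range from 0.05 to 0.2.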

Compound 4, unbound fraction: 0.19
Beside the measured number, compound 4's estimate is 1.9-fold (0.28 log units) below it, and the stated range covers the measured number.
By their numbers in this assay, from the lowest: compounds 1 and 3 (each within the scatter of the next); then compounds 2 and 4 (each within the scatter of the next).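

At the amide-type nitrogen, the number in this assay depends on the group carried: the change to 4-hydroxycyclohexyl gives a 2.7-fold higher number from compound 3 to compound 4 (0.43 log units; beyond the scatter), and measured against isopropyl it gives a 3.2-fold higher number from compound 1 to compound 4 (0.50 log units; beyond the scatter), whereas the earlier swap on this nitrogen gave only a 1.2-fold higher number from compound 1 to compound 3 (0.07 log units; within the scatter). A six-membered non-aromatic ring of carbon only is present in both the leaving group and the entering group, so that ring alone does not account for the step; what differs is the substitution on it, with 1 hydrogen-bond donor in the entering group and 0 in the leaving group. No measurement at hand explains the shift.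

On these data alone, whether the hydroxy itself is what matters remains open, and an amine or a methoxy group in its place on the cyclohexyl ring, or the opposite stereochemistry of 4-hydroxycyclohexyl, would test this. Also open, as far as these compounds go, is whether 4-hydroxycyclohexyl on this nitrogen and the fluoro change seen in a 3.0-fold higher number from compound 1 to compound 2 (0.48 log units; beyond the scatter) would add up when carried together on the shared core.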